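This account rests on a few compounds, and the source may have more. Where it says the series, first, only, none or still open, it means among the compounds named here.

Measured in a functional assay on PC-9 cells (Homo sapiens) for inhibition, read by MTT assay, with a stated time of 72 h; on this read-out higher numbers stand for weaker inhibition and lower numbers for stronger inhibition:
- Compound 1 `Cc1cc(Nc2ccn(Cc3cccc4ccccc34)n2)n2nc(SCc3ccc(Br)cc3)nc2n1`: 5660 nM.
- Compound 2 `Cc1cc(Nc2ccn(Cc3ccccc3)n2)n2nc(SCc3ccc(Br)cc3)nc2n1`: > 50000 nM, a limit of the assay.
- Compound 3 `Cc1cc(Nc2cc(-c3ccccc3)[nH]n2)n2nc(SCc3cccc(Br)c3)nc2n1`: 8900 nM.

Compound 2 has no number, only a limit (the limit of > 50000 nM in this assay, at which 1 of the 3 values shown sits). Compound 4 `Cc1cc(Nc2ccn(Cc3ccc(F)cc3)n2)n2nc(SCc3ccc(Br)cc3)nc2n1` differs from it by fluoro in place of hydrogen on an aromatic carbon, para to a large group, taking benzyl to 4-fluorobenzyl (fluoro in place of hydrogen on an aromatic carbon). For the measured compounds named here, the only measured step on this side chain is an at least 8.8-fold higher number from compound 1 to compound 2 (0.94 log units; beyond the scatter), which is beyond the scatter but is a change of a different kind. Going by the values given here, no measured step covers fluoro. That step therefore gives only weak guidance, and compound 4 is expected to stay close to the limit, with any shift towards a lower number. The expected step is small, estimated as an at least 1.2-fold lower number from compound 2 to compound 4 (0.09 log units; that floor lies within the scatter). For compound 4 the estimated value is 40000 nM, with an expected range of 12000 nM to 60000 nM.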

Compound 4, half-maximal inhibitory concentration: 19400 nM
For compound 4 the middle estimate is 2.1-fold (0.31 log units) above the measured one; low and high end bracket the measured number.
By their numbers in this assay, from the lowest: compounds 1 and 3 (each within the scatter of the next); then compound 4. At a limit, above all of these: compound 2.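

In this assay, 4-fluorobenzyl in place of benzyl gives an at least 2.5-fold lower number from compound 2 to compound 4 (0.41 log units; beyond the scatter), so this side chain responds to a single fluoro and not only to the change from naphthalen-1-yl. That step is only a floor, and its true size cannot be read, because compound 2 stands at a limit: the limit of > 50000 nM in this assay, at which 1 of the 4 values shown sits. The 4-fluorophenyl group still falls short of naphthalen-1-yl, with a 3.4-fold higher number from compound 1 to compound 4 (0.53 log units; beyond the scatter).

As far as these compounds go, whether chloro, methoxy or an amine at this same place would go further remains open. So does whether fluoro elsewhere on the ring would give a similar step.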